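The source may hold more compounds than are shown below. What is called first, only, known or untested is meant among the compounds shown, and "the series" means these compounds.

Among the compounds with values here, in a functional assay on HL-60 cells (Homo sapiens) for inhibition, read by MTT assay, with a stated time of 72 h (a lower number here means a stronger inhibitor, a higher number a weaker inhibitor), compound 1 `Cc1cc(C)cc(N2CCN(C(=O)c3oc(C)nc3-c3ccccc3)CC2)c1` gives 34.5 nM, while compound 2 `CC(=O)Nc1cccc(N2CCN(C(=O)c3oc(C)nc3-c3ccccc3)CC2)c1` gives 329 nM, the higher and therefore weaker of the two numbers measured so far. Within the data shown here, these two compounds differ only in the group on an amine nitrogen in a ring, and a 9.5-fold higher number from compound 1 to compound 2 (0.98 log units; beyond the scatter) is the only measured step at that place. Compound 3 `Cc1nc(-c2ccccc2)c(C(=O)N2CCN(c3ccccc3F)CC2)o1` changes the same place, with 2-fluorophenyl in place of 3-acetamidophenyl on an amine nitrogen in a ring. Among the measured compounds shown here, no compound carrying 2-fluorophenyl has been measured, so the guide is indirect. Like compound 1 at 34.5 nM, compound 3 lacks the acetamido group, so it is expected to recover part of the measured step, though not necessarily all of it. The expected change is a 3.3-fold lower number from compound 2 to compound 3 (0.52 log units; beyond the scatter). For compound 3 the estimate is 100 nM, with an expected range from 30 nM to 330 nM.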

Compound 3, half-maximal inhibitory concentration: 147 nM
Compound 3: the middle estimate sits 1.5-fold (0.17 log units) below what was measured, within the range that was stated.
By their numbers in this assay, from the lowest: compound 1; then compound 3; then compound 2.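

Compound 3 shows that losing the acetamido group is not enough on its own to reach the level of compound 1. The switch to 2-fluorophenyl brings a 2.2-fold lower number from compound 2 to compound 3 (0.35 log units; beyond the scatter), yet the 3,5-dimethylphenyl group still holds an edge, with a 4.3-fold higher number from compound 1 to compound 3 (0.63 log units; beyond the scatter), so this place on the ring nitrogen now separates three groups rather than two. Nothing available explains this order.

The 2-fluorophenyl and 3,5-dimethylphenyl groups differ in both the kind and number of their attached groups, so the compounds shown cannot say which difference matters. Also open, as far as these compounds go, is where an unsubstituted phenyl, a 3-methylphenyl or a 2-chlorophenyl group would fall in this order.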